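The source may report more compounds than this note shows. Statements on the series, on what has been measured and on what is new or still open speak of the compounds shown alone.

Measured in a functional assay on HCT-116 cells (Homo sapiens) for cytotoxicity, read by MTT assay, with a stated time of 72 h; a higher number here means a weaker inhibitor, a lower number a stronger inhibitor:
- Compound 1 `COc1cc(Nc2nc3ccccc3nc2S(=O)(=O)c2ccc(C)cc2)cc(OC)c1`: > 50000 nM, a limit of the assay and not a number.
- Compound 2 `COc1ccc(S(=O)(=O)c2nc3ccccc3nc2Nc2cc(OC)cc(OC)c2)cc1`: 13400 nM.
- Compound 3 `COc1ccc(S(=O)(=O)c2nc3ccccc3nc2Nc2cc(OC)c(OC)c(OC)c2)cc1`: > 50000 nM, a limit of the assay and not a number.

Compound 2 is the only one of the three with a number, at 13400 nM. The other two stand at the limit of > 50000 nM in this assay, at which 2 of the 3 values shown sit.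

Compound 4 `COc1ccc(S(=O)(=O)c2nc3ccccc3nc2Nc2ccc(Cl)cc2)cc1` has 4-chlorophenyl in place of 3,5-dimethoxyphenyl on a nitrogen on an aromatic ring.

Within the data shown here, two measured steps bear on this change. The closer guide is an at least 3.7-fold higher number from compound 2 to compound 3 (0.57 log units; beyond the scatter), with methoxy in place of hydrogen on an aromatic carbon of the group that leaves here. The other is an at least 3.7-fold lower number from compound 1 to compound 2 (0.57 log units; beyond the scatter), with methoxy in place of methyl on an aromatic carbon of the other aryl group. Among the measured compounds shown here, both show that a single change away from compound 2 can end at the limit, though no measured compound carries 4-chlorophenyl. A move to a higher number in this assay is therefore expected, of modest size and with wide uncertainty.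

The expected step is a 2.2-fold higher number from compound 2 to compound 4 (0.35 log units; beyond the scatter).

The estimated value for compound 4 is 30000 nM, with an expected range from 8000 nM to 80000 nM.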

Compound 4, half-maximal inhibitory concentration: 26500 nM
Beside the measured number, compound 4's estimate is 1.1-fold (0.05 log units) above it, and the stated range covers the measured number.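

In this assay, replacing 3,5-dimethoxyphenyl with 4-chlorophenyl on the nitrogen gives a 2.0-fold higher number from compound 2 to compound 4 (0.30 log units; within the scatter), so this change cannot be told apart from repeated measurement. The earlier compounds shown here tied this aryl group only to methoxy substitution, whereas compound 4 shows that a group with no methoxy at all can still give a measured number at this place, with chlorine as its only substituent. Compound 3 stands at > 50000 nM, a limit of the assay and not a number, so adding a methoxy to compound 2 and exchanging its aryl group for 4-chlorophenyl are separate cases, and the tolerance seen in compound 4 does not extend to every change on this ring.

The compounds shown do not tell whether the chlorine contributes anything, since a plain phenyl, a fluorine or a dimethylamino group at the same place would be needed to judge that. Going by these compounds, it also stays open whether 4-chlorophenyl would keep a measured number when paired with the methyl-bearing aryl group of compound 1, or whether a carboxylic acid on this ring would be tolerated.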